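The source may report more compounds than this note shows. Statements on the series, on what has been measured and on what is new or still open speak of the compounds shown alone.

Compound 1 `CCCNc1cc(Oc2ccc(NC(=O)Nc3cccc(C(F)(F)F)c3)cc2)ncn1` and compound 2 `CNc1cc(Oc2c(C)cc(NC(=O)Nc3cccc(C(F)(F)F)c3)cc2C)ncn1` share one core, and neither differs from the other in a single place. In an assay on isolated protein for inhibition of serine/threonine-protein kinase TNNI3K (Homo sapiens) (on this read-out lower numbers stand for stronger inhibition and higher numbers for weaker inhibition), compound 1 gives 32 nM, the higher of the two numbers shown. Compound 2 gives 25 nM in this assay, a gap that lies within the usual scatter. Compound 3 `CC(C)(O)CNc1cc(Oc2ccc(NC(=O)Nc3cccc(C(F)(F)F)c3)cc2)ncn1` differs from compound 1 by 1-hydroxy-1-methylethyl in place of ethyl on a saturated chain carbon bound to a nitrogen on an aromatic ring. Among the measured compounds shown here, no measured step of this kind is at hand, so the expected step of a 1.1-fold lower number from compound 1 to compound 3 (0.03 log units; within the scatter) is small and not beyond the scatter. Compound 3 is estimated to give 30 nM in this assay, within a range from 10 nM to 90 nM.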

Compound 3, half-maximal inhibitory concentration: 40 nM
Beside the measured number, compound 3's estimate is 1.3-fold (0.12 log units) below it, and the stated range covers the measured number.
By their numbers in this assay, from the lowest: compounds 2, 1 and 3 (each within the scatter of the next).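

In this assay, 1-hydroxy-1-methylethyl in place of ethyl on a saturated chain carbon bound to a nitrogen on an aromatic ring gives a 1.3-fold higher number from compound 1 to compound 3 (0.10 log units; within the scatter) and so provides the first step read at this position. The larger group, with its hydrogen-bond donor and acceptor, leaves the number within the scatter. Nothing at hand bears on why this is so. As far as these compounds go, whether an amine, a carboxylic acid or a longer chain at this place would also leave the number within the scatter stays open. So does the effect of this same change on the core of compound 2.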